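Reduction of the formyl group on a brominated catechol scaffold

This account rests on a few compounds, and the source may have more. Where it says the series, first, only, none or still open, it means among the compounds named here.

Compound 1 `O=Cc1cc(O)c(O)c(Br)c1Br` gives 30900 nM in a functional assay on DLD-1 cells (Homo sapiens) for cytotoxicity, read by MTT assay, with a stated time of 96 h (a lower number here means a stronger inhibitor, a higher number a weaker inhibitor), the lowest of the three numbers available. Compound 2 `COCc1cc(O)c(O)c(Br)c1` gives 35300 nM in this assay, a number that sits close to that of compound 1, and compound 3 `COc1cc(C=O)c(Br)c(Br)c1O` gives 91300 nM in this assay. For the measured compounds named here, the one change that can be followed between measured compounds is a 3.0-fold higher number from compound 1 to compound 3 (0.47 log units; beyond the scatter), a modest loss. Compound 4 `OCc1cc(O)c(O)c(Br)c1Br` has not yet been measured and differs from compound 1 as follows: hydroxymethyl in place of formyl on an aromatic carbon. Going by the values given here, no measured pair bears on this exact change; the one measured step concerns a different position, and compound 2 differs from compound 1 in more than one place. The change keeps the core untouched and swaps one two-atom group for another, so only a small step is expected, if any, in this assay, and a slight drift toward a higher number is judged somewhat more likely. The step from compound 1 to compound 4 is therefore expected to be a 1.5-fold higher number from compound 1 to compound 4 (0.16 log units; within the scatter). Compound 4 is estimated to give 45000 nM in this assay, within a range of 18000 nM to 110000 nM.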

Compound 4, half-maximal inhibitory concentration: 18300 nM
Beside the measured number, compound 4's estimate is 2.5-fold (0.39 log units) above it; low and high end bracket the measured number.
By their numbers in this assay, from the lowest: compounds 4, 1 and 2 (each within the scatter of the next); then compound 3.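

For the compounds shown here, this is the first step that can be followed at the aromatic carbon carrying the formyl group of compound 1, as the earlier step concerned a methyl on a ring oxygen. In this assay hydroxymethyl in place of formyl gives a 1.7-fold lower number from compound 1 to compound 4 (0.23 log units; within the scatter) and so leaves the number unchanged within the scatter, which shows that the double bond of the formyl group is not needed to hold the number at this level and that adding a hydrogen-bond donor here does not shift it. Nothing measured here gives a reason for this result.

On these data alone, it remains open whether an amine, a carboxylic acid or a longer chain on this carbon would also leave the number in place. As far as these compounds go, it is equally open whether hydroxymethyl would do the same on the methylated scaffold of compound 3.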